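Swapping a furan ring for bromine on the aryl arm

This account rests on a few compounds, and the source may have more. Where it says the series, first, only, none or still open, it means among the compounds named here.

Measured so far:
compound 1, `SC1=NC(n2nc(-c3ccccc3)nc2-c2ccccc2)=CC(c2ccccc2Cl)N1`: 30 mg/kg
compound 2, `SC1=NC(n2nc(-c3ccccc3)nc2-c2ccccc2)=CC(c2ccc(-c3ccco3)cc2)N1`: 30 mg/kg

Both compounds share one core and differ only in the aryl group on a saturated ring carbon. In a functional assay on the whole organism with Mus musculus as the target, in the maximal electroshock model, with a stated time of 0.5 h (on this read-out higher numbers stand for an effect only at larger amounts of compound and lower numbers for an effect already at smaller amounts), compound 1 gives 30 mg/kg, and compound 2 gives 30 mg/kg, so compound 2 stands level with compound 1; the step of no change at the digits printed from compound 1 to compound 2 (within the scatter) lies within the scatter.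

Compound 3, `SC1=NC(n2nc(-c3ccccc3)nc2-c2ccccc2)=CC(c2ccc(Br)cc2)N1`, is not yet measured. It differs from compound 2 by bromo in place of furan-2-yl on an aromatic carbon. For the measured compounds named here, no measured step covers this exact exchange. Going by the values given here, the only step available, no change at the digits printed from compound 1 to compound 2 (within the scatter), shows that replacing one aryl group by another, including a change from a halogen-bearing ring to a furan-bearing ring, left the result unchanged within the scatter. Among the compounds with values here, because of no change at the digits printed from compound 1 to compound 2 (within the scatter) the aryl substituent appears tolerant of variation so far, and compound 3 is therefore expected to show no change at the digits printed from compound 2 to compound 3 (within the scatter), no change beyond the scatter.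

Compound 3 is estimated to give 30 mg/kg in this assay, within a range from 10 mg/kg to 100 mg/kg.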

Compound 3, minimum effective dose: 100 mg/kg
For compound 3 the middle estimate is 3.3-fold (0.52 log units) below the measured one, and the stated range covers the measured number.
By their numbers in this assay, from the lowest: compounds 1 and 2 (each within the scatter of the next); then compound 3.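

In this assay, the aryl arm on the saturated ring carbon turns out not to be indifferent to what it carries: bromo in place of furan-2-yl, on an aromatic carbon para to a large group, gives a 3.3-fold higher number from compound 2 to compound 3 (0.52 log units; beyond the scatter). Exchanging the whole arm tells the same story, since 4-bromophenyl in place of 2-chlorophenyl gives a 3.3-fold higher number from compound 1 to compound 3 (0.52 log units; beyond the scatter). Compound 1 and compound 2 alone suggested that this position accepted different aryl groups without any visible change, but compound 3 shows that at least one aryl group separates from them, so an effect now requires a larger dose, although both steps are only modest.

Nothing measured here explains why the 4-bromophenyl arm stands apart from the other two. For the compounds shown here, with only three aryl groups in view, it remains open whether the shift belongs to bromo itself or whether any small group at this aromatic carbon would behave alike, and an amine or a carboxylic acid in place of bromo would show whether compound 3 or compound 2 is the more typical case.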